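A few compounds are considered here, and "the series" means these few. Any claim that something is new, unique, unknown or untested is made for them only; others in the source may bear on it.

Measured compounds: compound 1 `COc1cc(Oc2cccc(Nc3ccccc3)c2)cc(OC)c1CNCCNC(C)=O` gives 3960 nM in a functional assay on HT-29 cells (Homo sapiens) for inhibition, read by MTT assay, with a stated time of 72 h; on this read-out higher numbers stand for weaker inhibition and lower numbers for stronger inhibition; compound 2 `COc1ccc([C@@H](C)NCc2c(OC)cc(Oc3cccc(Nc4ccccc4)c3)c(OC)c2OC)cc1` gives 1630 nM; compound 3 `COc1cc(Oc2cccc(Nc3ccccc3)c2)cc(OC)c1CCO` gives 13900 nM.

Among these three, compound 1 stands second highest, with compound 2 lower and compound 3 higher. The unmeasured compound 4 `COc1cc(Oc2cccc(Nc3ccccc3)c2)cc(OC)c1CNC1CC1` differs from compound 1 in one place: cyclopropyl in place of 2-acetamidoethyl on an amine nitrogen. Among the compounds with values here, the only measured step that bears on this is a 3.5-fold higher number from compound 1 to compound 3 (0.55 log units; beyond the scatter), where the amine was lost altogether; compound 4 keeps the amine and changes only its substituent. Compound 2, with a different substituent on the amine, shows a lower number than compound 1. A step within the scatter is therefore expected, a 1.1-fold lower number from compound 1 to compound 4 (0.05 log units; within the scatter). For compound 4 the estimate is 3500 nM, between 1500 nM and 9000 nM.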

Compound 4, half-maximal inhibitory concentration: 12300 nM
For compound 4 the middle estimate is 3.5-fold (0.55 log units) below the measured one; the measured number lies above the stated range.
By their numbers in this assay, from the lowest: compound 2; then compound 1; then compounds 4 and 3 (each within the scatter of the next).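

In this assay, keeping the amine is not enough to hold the number of compound 1: a 3.1-fold higher number from compound 1 to compound 4 (0.49 log units; beyond the scatter), with cyclopropyl in place of 2-acetamidoethyl on the amine nitrogen. The other step, a 1.1-fold lower number from compound 3 to compound 4 (0.05 log units; within the scatter), lies within the scatter, so this one substituent change leaves compound 4 indistinguishable from compound 3, which has hydroxymethyl and no amine at that place. Nothing measured here accounts for this result.

The compounds shown leave open whether the acetamide end or the chain itself goes with the lower number of compound 1. A plain ethyl or a 2-aminoethyl group on the same nitrogen would separate the two.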